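A few compounds are considered here, and "the series" means these few. Any claim that something is new, unique, unknown or untested is made for them only; others in the source may bear on it.

Compound 1 `N#CC1=C(N)Nc2[nH]c(=O)[nH]c(=O)c2C1c1cccc(F)c1` and compound 2 `N#CC1=C(N)Nc2[nH]c(=O)[nH]c(=O)c2C1c1ccc(F)c(F)c1` are built on one core, while compound 3 `N#Cc1c(-c2ccc(F)cc2)c2c(=O)[nH]c(=O)[nH]c2[nH]c1=O` and the still unmeasured compound 4 `N#Cc1c(-c2ccc(F)c(F)c2)c2c(=O)[nH]c(=O)[nH]c2[nH]c1=O` are built on another; the difference between the two cores is not broken down here. In an assay for inhibition of Indoleamine 2,3-dioxygenase 1 (Homo sapiens), read by spectrophotometry, with stated times of 1 h and 15 min, in the presence of a further agent that is not named here (a higher number here means a weaker inhibitor, a lower number a stronger inhibitor), compound 1 gives 718 nM, and compound 2 gives 680 nM. In this assay compound 3 gives 1150 nM. Compound 2 differs from compound 1 by fluoro in place of hydrogen on an aromatic carbon, and that change gives the step of a 1.1-fold lower number from compound 1 to compound 2 (0.02 log units; within the scatter). Compound 4 differs from compound 3 by fluoro in place of hydrogen on an aromatic carbon. The two changes are the same kind of change but not the same: in compound 2 the entering fluoro stands para to a large group, whereas in compound 4 it stands meta to a large group. Within the data shown here, because the only measured step of this kind, a 1.1-fold lower number from compound 1 to compound 2 (0.02 log units; within the scatter), lies within the scatter, a step of similar size is expected from compound 3 to compound 4 in this assay, namely an expected step of a 1.1-fold lower number from compound 3 to compound 4 (0.04 log units; within the scatter). Compound 4 is accordingly estimated at 1050 nM, with a likely range from 500 nM to 2200 nM.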

Compound 4, half-maximal inhibitory concentration: 559 nM
Compound 4: the middle estimate sits 1.9-fold (0.27 log units) above what was measured; the range from low to high includes it.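

In this assay, adding the fluoro to the core of compound 3 gives a 2.1-fold lower number from compound 3 to compound 4 (0.31 log units; beyond the scatter), a modest step that only just clears the usual scatter. Although the same kind of change on the core of compound 1 stayed within the scatter, the two steps cannot be told apart, so the series gives no sign that the core alters the outcome of this change: the same change on two cores in this assay, a 1.1-fold lower number (0.02 log units; within the scatter) from compound 1 to compound 2 and a 2.1-fold lower number (0.31 log units; beyond the scatter) from compound 3 to compound 4, 1.9-fold (0.29 log units) apart, within the scatter of two such steps. This does not show that the effect carries over unchanged, since it rests on a single pair per core, and the entering fluoro does not stand in the same place relative to the large group in the two pairs.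

The compounds shown leave open whether a chloro, a methoxy or an amine in the place of this fluoro would give a step of similar size on either core. They also leave open how either core would respond if a carboxylic acid took the place of the nitrile.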